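The compounds below may be only part of what the source reports. "The series", "measured", "known", "first", "only" and "open" are said of these compounds alone.

Measured in a functional assay on MCF7 cells (Homo sapiens) for antiproliferative activity, read by sulforhodamine B assay, with a stated time of 48 h; on this read-out lower numbers stand for stronger inhibition and higher numbers for weaker inhibition:
- compound 1 `O=C1NCCN1c1ccc(S(=O)(=O)Nc2ccc(Br)cc2)cc1`: 240 nM
- compound 2 `COc1ccc(NS(=O)(=O)c2ccc(N3CCNC3=O)cc2)cc1`: > 1000 nM (a limit of the assay, not a number)

Compound 2 has no number, only (the limit of > 1000 nM in this assay, at which 1 of the 2 values shown sits). Compound 3 `COc1ccccc1NS(=O)(=O)c1ccc(N2CCNC2=O)cc1` changes the group on the sulfonamide nitrogen: 2-methoxyphenyl in place of 4-methoxyphenyl on a sulfonamide nitrogen. Going by the values given here, the only measured step, an at least 4.1-fold higher number from compound 1 to compound 2 (0.61 log units; beyond the scatter), is beyond the scatter, but it puts methoxy in place of bromo and does not move the methoxy, so it bears on this change only indirectly. No clear change beyond the scatter is expected, and the estimated step is a step that the limit leaves unreadable from compound 2 to compound 3. For compound 3 the expected value is 1200 nM, with an estimated range of 350 nM to 4000 nM.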

Compound 3, half-maximal inhibitory concentration: 770 nM
Estimate against measurement, compound 3: 1.6-fold (0.19 log units) above; the measured number falls inside the stated range.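

In this assay compound 3 gives the first real number for a methoxyphenyl group on the sulfonamide nitrogen, while compound 2 holds only a limit: the limit of > 1000 nM in this assay, at which 1 of the 3 values shown sits.

Moving the methoxy shows an at least 1.2-fold lower number from compound 2 to compound 3 (0.11 log units; that floor lies within the scatter), so no gain from 2-methoxyphenyl can be claimed, though a larger gap stays possible. The comparison with bromo now has a size, with a 3.2-fold higher number from compound 1 to compound 3 (0.51 log units; beyond the scatter).

Open, as far as these compounds go, is how a 2-bromophenyl group would compare with the 4-bromophenyl group of compound 1. Also open, from the compounds shown here alone, is how an amine or a carboxylic acid on that aromatic ring would read.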